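Catechol stilbene amides: trading the amide for an enal

The source may report more compounds than this note shows. Statements on the series, on what has been measured and on what is new or still open speak of the compounds shown alone.

Measured compounds:
- compound 1, `C=CCNC(=O)c1ccc(/C=C/c2ccc(O)c(O)c2)cc1`: 1.95 uM
- compound 2, `O=C(NCc1ccco1)c1ccc(/C=C/c2ccc(O)c(O)c2)cc1`: 0.82 uM

In a functional assay on BV-2 cells (Mus musculus) for inhibition, with a stated time of 24 h (on this read-out higher numbers stand for an effect only at larger amounts of compound and lower numbers for an effect already at smaller amounts), compound 1 gives 1.95 uM, the highest of the two numbers shown; its nearest neighbour is compound 2, which is reached by a 2.4-fold lower number from compound 1 to compound 2 (0.38 log units; beyond the scatter) through exchange of the group on the amide-type nitrogen. Compound 3, `O=C/C=C/c1ccc(/C=C/c2ccc(O)c(O)c2)cc1`, has not yet been measured. It differs from compound 1 by 2-formylethenyl in place of allylcarbamoyl on an aromatic carbon, so the amide of the shared core gives way to an unsaturated aldehyde. No measured step touches this part of the molecule: the only step shown, from compound 1 to compound 2, alters the substituent on the nitrogen and leaves the amide itself in place, so it offers no direct guide. Compound 3 is therefore expected to stay near compound 1, with a step of about a 1.3-fold lower number from compound 1 to compound 3 (0.11 log units; within the scatter) and no confident direction. The estimate for compound 3 in this assay is 1.5 uM, within 0.4 uM to 6 uM.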

Compound 3, concentration for half-maximal effect: 1.51 uM
Estimate against measurement, compound 3: 1.0-fold (0.00 log units) below; the measured number falls inside the stated range.
By their numbers in this assay, from the lowest: compounds 2, 3 and 1 (each within the scatter of the next, the first and the last beyond it).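

In this assay, within the data shown here, the earlier compounds changed only the group on the amide nitrogen, whereas here the amide itself goes, with 2-formylethenyl in place of allylcarbamoyl on an aromatic carbon para to a large group. The result is a 1.3-fold lower number from compound 1 to compound 3 (0.11 log units; within the scatter), so at this position the read-out does not separate the two groups, even though the entering group carries no hydrogen-bond donor and the leaving group does. Nothing available accounts for this outcome.

The compounds shown leave open whether the aldehyde carbonyl or the chain's carbon-carbon double bond matters at this position, since both are present together in compound 3. A carboxylic acid, a primary alcohol or a saturated propanal chain in the same place would separate these two features.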